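The source may report more compounds than this note shows. Statements on the series, on what has been measured and on what is new or still open speak of the compounds shown alone.

In a functional assay on A549 cells (Homo sapiens) for antiproliferative activity, read by MTT assay, with a stated time of 72 h (a lower number here means a stronger inhibitor, a higher number a weaker inhibitor), compound 1 `COc1ccccc1-c1ccc2ncn(-c3cc(OC)c(OC)c(OC)c3)c2c1` gives 4320 nM. Compound 2 `COc1ccc(-c2ccc3ncn(-c4cc(OC)c(OC)c(OC)c4)c3c2)cc1` gives > 10000 nM, which is a limit and not a number. Compound 3 `COc1cccc(-c2ccc3ncn(-c4cc(OC)c(OC)c(OC)c4)c3c2)c1` differs from compound 2 by 3-methoxyphenyl in place of 4-methoxyphenyl on an aromatic carbon, with 3-methoxyphenyl in place of 4-methoxyphenyl on an aromatic carbon. Among the compounds with values here, the only measured step bearing on this, an at least 2.3-fold higher number from compound 1 to compound 2 (0.36 log units; beyond the scatter), places 4-methoxyphenyl where 2-methoxyphenyl stood. On that single step, a modest move toward a lower number in this assay is expected, and the estimated change is an at least 1.4-fold lower number from compound 2 to compound 3 (0.15 log units; that floor lies within the scatter). The estimate for compound 3 is 7000 nM, with an expected range of 3000 nM to 15000 nM.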

Compound 3, half-maximal inhibitory concentration: 3180 nM
The estimate for compound 3 lay 2.2-fold (0.34 log units) above the measured number; measured number inside the range.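

On this aromatic carbon, the earlier pair could not show whether 2-methoxyphenyl was the favoured arrangement or 4-methoxyphenyl the poor one; among these three compounds, the second reading holds. In this assay, 3-methoxyphenyl and 2-methoxyphenyl cannot be told apart, with a 1.4-fold lower number from compound 1 to compound 3 (0.13 log units; within the scatter), while 3-methoxyphenyl separates from 4-methoxyphenyl, with an at least 3.1-fold lower number from compound 2 to compound 3 (0.49 log units; beyond the scatter). Compound 2 carries a limit and not a number, so its steps are floors only: the limit of > 10000 nM in this assay, at which 1 of the 3 values shown sits.

Open, going by these compounds, is how far compound 2 truly lies from the other two. Also open, on these data alone, is how an unsubstituted phenyl, a 3-hydroxyphenyl or a 3-aminophenyl would read on this carbon.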